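Moving the Chlorine: From Compound 2 to Compound 3

This account rests on a few compounds, and the source may have more. Where it says the series, first, only, none or still open, it means among the compounds named here.

Compound 1, `CC1=C(C(=O)Nc2ccc(F)cc2)C(c2ccc([N+](=O)[O-])cc2)N=C(SCc2ccc(Cl)cc2)N1`, in a functional assay on the whole organism (artery, strain albino) with Rattus norvegicus as the target, with a stated time of 15 min, at a dose of 10 mg/kg by the oral route (on this read-out lower numbers stand for less inhibition and higher numbers for more inhibition at the one dose given (going by the name of the read-out)), gives 3.6%.
Compound 2, `CC1=C(C(=O)Nc2ccc([N+](=O)[O-])cc2)C(c2ccc(Br)cc2)N=C(SCc2ccccc2Cl)N1`, in this assay gives 1.5%.

Compound 2 has the lowest of the two numbers, but the gap to compound 1 lies within the usual scatter, so the two measurements cannot be told apart. Compound 3, `CC1=C(C(=O)Nc2ccc([N+](=O)[O-])cc2)C(c2ccc(Br)cc2)N=C(SCc2ccc(Cl)cc2)N1`, differs from compound 2 in one place: 4-chlorophenyl in place of 2-chlorophenyl on a saturated chain carbon bound to a sulfur. Going by the values given here, no measured pair shows this change, and both measured compounds sit near the bottom of the scale, so no step beyond the scatter is expected here: a number 1.5 percentage points higher from compound 2 to compound 3 (within the scatter). Compound 3 is estimated at 3%, with a range from 0% to 12%.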

Compound 3, a percentage reported as inhibition, in the whole organism at one dose (the size of the read-out at that dose, not a potency): 3.1%
Beside the measured number, compound 3's estimate is 0.1 percentage points below it, and the stated range covers the measured number.
By their numbers in this assay, from the lowest: compounds 2, 3 and 1 (each within the scatter of the next).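

In this assay, going by these compounds alone, the placement of the chlorine on this ring can now be read directly for the first time: there is a number 1.6 percentage points higher from compound 2 to compound 3 (within the scatter), so 2-chlorobenzyl and 4-chlorobenzyl on the sulfur cannot be told apart here. No measurement at hand offers a reason for this result.

From the compounds shown here alone, all the numbers so far lie close to the bottom of the scale, so it remains open whether any group at this position can give a clearly higher number. The compounds shown also leave open what an amine or a carboxylic acid in place of the chlorine, or a longer chain on the sulfur, would do.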